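The source may report more compounds than this note shows. Statements on the series, on what has been measured and on what is new or still open speak of the compounds shown alone.

In a functional assay on A-375 cells (Homo sapiens) for inhibition, read by MTT assay, with a stated time of 120 h (a higher number here means a weaker inhibitor, a lower number a stronger inhibitor), compound 1 `CNC(=O)/C(C)=C/c1ccc(NC(=O)Nc2ccc(Cl)c(C(F)(F)F)c2)cc1` gives > 50000 nM, which is a limit of the assay. Among the measured compounds shown here, compound 2 `CNC(=O)c1cccc(-c2ccc(NC(=O)Nc3ccc(Cl)c(C(F)(F)F)c3)cc2)c1` gives 46500 nM, the only actual number so far. Compound 3 `CNC(=O)C#Cc1ccc(NC(=O)Nc2ccc(Cl)c(C(F)(F)F)c2)cc1` carries 2-(methylcarbamoyl)ethynyl in place of the 3-(methylcarbamoyl)phenyl of compound 2, on an aromatic carbon (2-(methylcarbamoyl)ethynyl in place of 3-(methylcarbamoyl)phenyl on an aromatic carbon). For the measured compounds named here, only one measured step bears on this exchange at the same place, and an at least 1.0-fold lower number from compound 1 to compound 2 (0.03 log units; that floor lies within the scatter) stays within the scatter. No change beyond the scatter is therefore expected in this assay, and the expected step is a 1.2-fold lower number from compound 2 to compound 3 (0.07 log units; within the scatter). For compound 3 the estimated value is 40000 nM, with an expected range of 10000 nM to 100000 nM.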

Compound 3, half-maximal inhibitory concentration: > 50000 nM
Compound 3: no number, only a limit (the forecaster's own chance of this, stated with the estimate: 50%); middle value at least 1.2-fold (0.09 log units) from the limit.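

In this assay, 2-(methylcarbamoyl)ethynyl in place of 3-(methylcarbamoyl)phenyl on this aromatic carbon gives an at least 1.0-fold higher number from compound 2 to compound 3 (0.03 log units; that floor lies within the scatter). For compound 3 the reading is > 50000 nM, which is a limit of the assay and not a number. The step between compound 1 and compound 3 cannot be read, so a triple-bonded chain without a ring, like the double-bonded chain before it, leaves the groups at this position unseparated: the limit of > 50000 nM in this assay, at which 2 of the 3 values shown sit.

As far as these compounds go, it stays open whether a carboxylic acid, an amine or a longer chain at this position would give a number clearly under that limit.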